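The source may report more compounds than this note shows. Statements on the series, on what has been measured and on what is new or still open speak of the compounds shown alone.

In a physicochemical assay for solubility, in phosphate buffer, measured as kinetic solubility, at pH 7.4 (a lower number here means a less soluble compound, a higher number a more soluble compound), compound 1 `Cc1ccc(C)c(-c2nc(CN3CCC(C(=O)NCCCN4C[C@H](C)C[C@H](C)C4)CC3)c(C)o2)c1` gives 56.1 ug/mL, compound 2 `Cc1oc(-c2c(Cl)cccc2C(F)(F)F)nc1CN1CCC(C(=O)NCCCN2C[C@H](C)C[C@H](C)C2)CC1` gives 65.1 ug/mL and compound 3 `CCc1ccccc1-c1nc(CN2CCC(C(=O)NCCCN3C[C@H](C)C[C@H](C)C3)CC2)c(C)o1` gives 55.9 ug/mL. Compound 3 therefore stands within the scatter of both others, with a 1.0-fold lower number from compound 1 to compound 3 (0.00 log units; within the scatter) and a 1.2-fold lower number from compound 2 to compound 3 (0.07 log units; within the scatter). Compound 4 `COc1ccc(-c2nc(CN3CCC(C(=O)NCCCN4C[C@H](C)C[C@H](C)C4)CC3)c(C)o2)cc1OC` has 3,4-dimethoxyphenyl in place of 2-ethylphenyl on an aromatic carbon of a five-membered aromatic ring with 1 nitrogen and 1 oxygen: 3,4-dimethoxyphenyl in place of 2-ethylphenyl on an aromatic carbon. All three measured steps bear on this change, since each exchanges the aryl group at this same place. The third is a 1.2-fold higher number from compound 1 to compound 2 (0.06 log units; within the scatter), and all three lie within the scatter. Going by the values given here, no measured compound carries 3,4-dimethoxyphenyl, so the data give no direct reading on that group and favour no direction. No step beyond the scatter is expected in this assay, though the range stays wide for the untested group. The expected step is a 1.1-fold higher number from compound 3 to compound 4 (0.04 log units; within the scatter). Compound 4 is estimated at 62 ug/mL, with an expected range from 35 ug/mL to 110 ug/mL.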

Compound 4, solubility: > 76 ug/mL
Compound 4 gave a limit, no number; the forecaster's own chance of this, stated with the estimate: 5%; at least 1.2-fold (0.08 log units) between middle value and limit.
By their numbers in this assay, from the lowest: compounds 3, 1 and 2 (each within the scatter of the next). At a limit, above all of these: compound 4.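

Going by these compounds alone, compound 4 gives a limit in this assay, not a number, and it is the only compound of the four to do so: the limit of > 76 ug/mL in this assay, at which 1 of the 4 values shown sits. The steps to it are floors, an at least 1.3-fold higher number from compound 3 to compound 4 (0.13 log units; that floor lies within the scatter), an at least 1.3-fold higher number from compound 1 to compound 4 (0.13 log units; that floor lies within the scatter) and an at least 1.1-fold higher number from compound 2 to compound 4 (0.06 log units; that floor lies within the scatter), so this change at the aryl place is not shown to exceed the scatter, though the true steps may be larger. Compared with 2-ethylphenyl, the 3,4-dimethoxyphenyl group adds 2 hydrogen-bond acceptors on the same six-membered aromatic ring, and this exchange gives the only reading at this place that is not a plain number.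

As far as these compounds go, how far compound 4 lies past its limit remains open, so the size of these steps cannot be read beyond their floors. Also open, from the compounds shown here alone, is how a single methoxy group, an amine or a carboxylic acid on the aryl ring would read at this place.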